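This account rests on a few compounds, and the source may have more. Where it says the series, first, only, none or still open, it means among the compounds named here.

Measured so far in a functional assay on MDA-MB-231 cells (Homo sapiens) for antiproliferative activity, read by MTT assay, with a stated time of 24 h; a higher number here means a weaker inhibitor, a lower number a stronger inhibitor:
compound 1, `O=C(NNc1ccccc1F)c1ccc(NS(=O)(=O)c2cnc(O)nc2O)cc1`, gives > 20000 nM, which is a limit of the assay rather than a number.
Compound 2, `O=C(NNc1ccc(F)cc1)c1ccc(NS(=O)(=O)c2cnc(O)nc2O)cc1`, gives > 20000 nM, again a limit of the assay.
Compound 3, `O=C(NNc1ccccc1F)c1ccccc1NS(=O)(=O)c1cnc(O)nc1O`, gives > 20000 nM, also a limit of the assay.

Compound 1 and compound 2 share a core and differ in one place: 4-fluorophenyl in place of 2-fluorophenyl on an amine nitrogen. The step that the two limits leave unreadable from compound 1 to compound 2 cannot be read, since both values sit at the limit; all that can be said of the pair is that neither reaches a measurable number. Compound 3 carries a different core, and the difference between the two cores of compound 1 and compound 3 is not broken down here.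

Compound 4, `O=C(NNc1ccc(F)cc1)c1ccccc1NS(=O)(=O)c1cnc(O)nc1O`, has not yet been measured in this assay. It stands to compound 3 as compound 2 stands to compound 1: 4-fluorophenyl in place of 2-fluorophenyl on an amine nitrogen. The place of the change is the same in both pairs, so this is the same change made on the second core.

The expectation rests on (the limit of > 20000 nM in this assay, at which 3 of the 3 values shown sit), at which every value seen so far sits. Compound 4 is therefore expected to show a step that the limit leaves unreadable from compound 3 to compound 4 from its parent, meaning no readable change. Compound 4 is estimated at 25000 nM in this assay. Compound 4 is expected to fall between 10000 nM and 60000 nM, with a strong likelihood that the assay again reports only a limit and no number.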

Compound 4, half-maximal inhibitory concentration: > 20000 nM
Compound 4 ended at the assay's limit (the forecaster's own chance of this, stated with the estimate: 85%); the middle value does not contradict the limit.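

No new step can be read: compound 3 and compound 4 both stop at a limit of the assay in this assay, so the change from 2-fluorophenyl to 4-fluorophenyl has no readable size on this core. The compounds shown leave open whether that change, or the difference between the two cores, affects antiproliferative activity at all, since none of them yields a number.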